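The source may report more compounds than this note shows. Statements on the series, on what has been measured and on what is new or still open speak of the compounds shown alone.

In an assay on microsomes from liver for inhibition of acyl-CoA desaturase 1 (Rattus norvegicus) (on this read-out higher numbers stand for weaker inhibition and lower numbers for stronger inhibition), compound 1 `OCc1nnc(-c2ccc(N3CCC(Oc4ccccc4C(F)(F)F)CC3)nn2)s1` gives 3.2 nM, the lowest of the two numbers available. For the measured compounds named here, the only other measured compound, compound 2 `N#Cc1ccccc1OC1CCN(c2ccc(-n3ccnc3)nn2)CC1`, gives 236 nM in this assay; the two differ in several places at once, so the pair shows only that compound 1 stands far lower, not which part of the structure accounts for the gap.

Compound 3 `CC(C)Cc1nnc(-c2ccc(N3CCC(Oc4ccccc4C(F)(F)F)CC3)nn2)s1` differs from compound 1 in one place: isopropyl in place of hydroxy on a saturated chain carbon bound to an aromatic carbon. Going by the values given here, no measured pair isolates this change, so the direction and size of the step can only be guessed from the standing of compound 1 and from the kind of change. An isopropyl entering where a hydroxy leaves, with one heavy atom replaced by three and both a donor and an acceptor removed, is expected to move the number only modestly, most likely toward a slightly higher value and possibly within the usual scatter. The step from compound 1 to compound 3 in this assay is therefore estimated at a 1.9-fold higher number from compound 1 to compound 3 (0.27 log units; within the scatter). Compound 3 is expected to give about 6 nM in this assay, within a range of 1.5 nM to 30 nM.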

Compound 3, half-maximal inhibitory concentration: 37 nM
Estimate against measurement, compound 3: 6.2-fold (0.79 log units) below; measured number above the stated range.
By their numbers in this assay, from the lowest: compound 1; then compound 3; then compound 2.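

With the rest of the structure unchanged, isopropyl in place of hydroxy on a saturated chain carbon bound to an aromatic carbon gives, in this assay, a 12-fold higher number from compound 1 to compound 3 (1.06 log units; beyond the scatter). This shows that the assay responds clearly to what this position carries: hydroxymethyl and isobutyl on the shared core do not stand alike, which the earlier pair, differing in several places at once, could not isolate. Nothing measured here bears on why the number rises with this change.

A single change cannot separate the departure of the hydroxy from the arrival of the isopropyl, so the compounds shown leave open whether the step belongs to the group that leaves, the group that enters, or both. They also leave open how a methoxy, an amine, a carboxylic acid or a longer chain would stand at this place, and whether the same change would give a step of similar size on a different core.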